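This account rests on a few compounds, and the source may have more. Where it says the series, first, only, none or still open, it means among the compounds named here.

Measured compounds in a functional assay on HCT-116 cells (Homo sapiens) for antiproliferative activity, read by MTT assay, with a stated time of 72 h; a higher number here means a weaker inhibitor, a lower number a stronger inhibitor:
compound 1 `COc1c(NS(=O)(=O)c2ccc(F)cc2)cc(-c2ccc3nc(NC4CC4)sc3n2)cc1C(N)=O`: 35700 nM
compound 2 `COc1c(NS(=O)(=O)c2ccc(F)cc2)cc(-c2ccc3nc(NC(=O)C4CC4)sc3n2)cc1C(N)=O`: 2500 nM
compound 3 `COc1c(NS(=O)(=O)c2ccc(F)cc2)cc(-c2ccc3nc(NC4CC4)sc3c2)cc1C(N)=O`: a limit only, > 50000 nM

Compound 3 sits at the limit of > 50000 nM in this assay, at which 1 of the 3 values shown sits. Compound 1 and compound 2 share a core; compound 3 carries another, and the difference between the two cores is not broken down here.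

Within the first core, the change cyclopropylcarbonyl in place of cyclopropyl on a nitrogen on an aromatic ring gave a 14-fold lower number from compound 1 to compound 2 (1.15 log units; beyond the scatter).

Compound 4 `COc1c(NS(=O)(=O)c2ccc(F)cc2)cc(-c2ccc3nc(NC(=O)C4CC4)sc3c2)cc1C(N)=O` carries the second core and the change (cyclopropylcarbonyl in place of cyclopropyl on a nitrogen on an aromatic ring); the place reads word for word as in the first pair, so it is the same change. The expected step is an at least 3.3-fold lower number from compound 3 to compound 4 (0.52 log units; beyond the scatter), resting on compound 1 and compound 2 because of a 14-fold lower number from compound 1 to compound 2 (1.15 log units; beyond the scatter). Compound 4 is estimated at 15000 nM, between 4000 nM and 50000 nM. The range is wide, as compound 3 gives only a limit.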

Compound 4, half-maximal inhibitory concentration: 2010 nM
Estimate against measurement, compound 4: 7.5-fold (0.87 log units) above; measured number outside the range, below it.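

In this assay the swap of cyclopropyl for cyclopropylcarbonyl on a nitrogen on an aromatic ring gives an at least 24-fold lower number from compound 3 to compound 4 (1.39 log units; beyond the scatter) on the second core, so the direction seen on the first core carries over to this one. This does not show that the size of the step carries over, and two cores say nothing about any other core in the series: the same change on two cores in this assay, a 14-fold lower number (1.15 log units; beyond the scatter) from compound 1 to compound 2 and an at least 24-fold lower number (1.39 log units; beyond the scatter) from compound 3 to compound 4; the limit leaves it open whether they differ. The reading for compound 3 is a limit and not a number: the limit of > 50000 nM in this assay, at which 1 of the 4 values shown sits.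

The compounds shown leave open how an acetyl group, a longer acyl chain or a urea on that nitrogen would compare with cyclopropylcarbonyl. They also leave open whether the step would hold with a group other than 4-fluorophenyl on the sulfonamide.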